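The source may hold more compounds than are shown below. What is called first, only, known or untested is meant among the compounds shown, and "the series" means these compounds.

Measured in the edema test:
compound 1, `N#Cc1c(-c2ccc(Cl)cc2)nc(SCC(=O)Nn2c(COc3ccc(Cl)cc3Cl)nc3ccccc3c2=O)[nH]c1=O`: 61.5%
compound 2, `N#Cc1c(-c2ccc(O)cc2)nc(SCC(=O)Nn2c(COc3ccc(Cl)cc3Cl)nc3ccccc3c2=O)[nH]c1=O`: 61.5%
compound 3, `N#Cc1c(Nc2ccc(Cl)cc2)nc(SCC(=O)Nn2c(COc3ccc(Cl)cc3Cl)nc3ccccc3c2=O)nc1-c1ccc(O)cc1`: 65.4%

All three were measured in a functional assay on the whole organism (strain albino) for inhibition, with Rattus norvegicus as the target, read by paw edema, with stated times of 1 h and 0.5 h, at a dose of 100 mg/kg by the oral route; a lower number here means less inhibition, a higher number more inhibition at the dose given (going by the name of the read-out). Compound 1 and compound 2 share one core and differ by hydroxy in place of chloro on an aromatic carbon; the step of no change at the digits printed from compound 1 to compound 2 (within the scatter). Compound 3 carries a different core; the difference between the two cores is not broken down here, and in this assay compound 3 gives 65.4%, a number within the scatter of compound 1 and compound 2 alike. Compound 4, `N#Cc1c(Nc2ccc(O)cc2)nc(SCC(=O)Nn2c(COc3ccc(Cl)cc3Cl)nc3ccccc3c2=O)nc1-c1ccc(O)cc1`, is not yet measured; it differs from compound 3 by hydroxy in place of chloro on an aromatic carbon, the same kind of change as that from compound 1 to compound 2. Because no change at the digits printed from compound 1 to compound 2 (within the scatter), the step of a number 1.4 percentage points lower from compound 3 to compound 4 (within the scatter) is expected to be small as well. Compound 4 is estimated at 64%, between 50% and 78%.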

Compound 4, a percentage reported as inhibition, in the whole organism at one dose (the size of the read-out at that dose, not a potency): 80.8%
For compound 4 the middle estimate is 16.8 percentage points below the measured one; the measured number lies above the stated range.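

In this assay, hydroxy in place of chloro gives a number 15.4 percentage points higher from compound 3 to compound 4 (beyond the scatter), so the change does not carry over at one size from the core of compound 1 to the core of compound 3: the same change on two cores in this assay, no change at the digits printed (within the scatter) from compound 1 to compound 2 and a number 15.4 percentage points higher (beyond the scatter) from compound 3 to compound 4, 15.4 percentage points apart, beyond the scatter of two such steps A step read on one of these cores therefore cannot simply be transferred to the other. For the compounds shown here, this rests on only two steps, and it does not show what in the cores sets them apart or how the change would behave on any further core.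

The compounds shown leave open how a methoxy group or an amine would read in that same place. They also leave open whether any such replacement would differ between the two cores.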